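Swapping a tert-butyl for a 4-methylbenzyl on the shared core

This account rests on a few compounds, and the source may have more. Where it says the series, first, only, none or still open, it means among the compounds named here.

Three compounds share one core and differ only in the group attached to it. Compound 1 `CC(C)(C)Cc1cnc(CCc2ccc(-c3ccccc3C(=O)O)cc2)[nH]1` gives 6.3 nM in an in vitro functional assay on cells for agonist activity at Bombesin receptor subtype-3 (Mus musculus), read by luminescence and calcium flux; on this read-out higher numbers stand for an effect only at larger amounts of compound and lower numbers for an effect already at smaller amounts. Compound 2 `N#Cc1ccc(Cc2cnc(CCc3ccc(-c4ccccc4C(=O)O)cc3)[nH]2)cc1` gives 723 nM, and compound 3 `CC(C)(C)c1cnc(CCc2ccc(-c3ccccc3C(=O)O)cc2)[nH]1` gives 2750 nM, the highest number of the three; its nearest neighbour is compound 2, at a 3.8-fold higher number from compound 2 to compound 3 (0.58 log units; beyond the scatter), and the widest gap is a 440-fold higher number from compound 1 to compound 3 (2.64 log units; beyond the scatter). Compound 4 `Cc1ccc(Cc2cnc(CCc3ccc(-c4ccccc4C(=O)O)cc3)[nH]2)cc1` differs from compound 3 by 4-methylbenzyl in place of tert-butyl on an aromatic carbon. The reverse of a 3.8-fold higher number from compound 2 to compound 3 (0.58 log units; beyond the scatter) bears most directly, and it was modest; a 110-fold higher number from compound 1 to compound 2 (2.06 log units; beyond the scatter) shows how wide the spread within such groups can be. A lower number than compound 3 is therefore expected for compound 4, roughly a 14-fold lower number from compound 3 to compound 4 (1.14 log units; beyond the scatter), giving an estimated 200 nM, with a range from 40 nM to 1000 nM.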

Compound 4, half-maximal effective concentration: 162 nM
Compound 4: middle estimate off by 1.2-fold (0.09 log units), on the high side; low and high end bracket the measured number.
By their numbers in this assay, from the lowest: compound 1; then compound 4; then compound 2; then compound 3.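

At this position on the shared core, adding the 4-methylbenzyl ring in place of tert-butyl matters a great deal (a step of a 17-fold lower number from compound 3 to compound 4 (1.23 log units; beyond the scatter)), and the group on that ring matters too, as methyl in place of cyano gives a smaller but real shift (a 4.5-fold lower number from compound 2 to compound 4 (0.65 log units; beyond the scatter)). Even so, neither benzyl group matches the neopentyl of compound 1 (a 26-fold higher number from compound 1 to compound 4 (1.41 log units; beyond the scatter)). No measurement here explains these differences. As far as these compounds go, whether an amine on the benzyl ring, or a longer chain ending in tert-butyl, would come closer to compound 1 remains open.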